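Pyridin-2-yl Replaces 5-Methyl-1,2-oxazol-3-yl on a Sulfonamide Nitrogen

The source may hold more compounds than are shown below. What is called first, only, known or untested is meant among the compounds shown, and "the series" means these compounds.

Compound 1 `O=C1CS/C(=N/Nc2nncc3ccccc23)N1c1ccccc1`: 7.9 nM
Compound 2 `NC(=S)NNc1nncc2ccccc12`: 0.8 nM
Compound 3 `Cc1cc(NS(=O)(=O)c2ccc(Nc3nncc4ccccc34)cc2)no1`: 6.7 nM

All three were tested in a functional assay on SK-OV-3 cells (Homo sapiens) for antiproliferative activity, read by sulforhodamine B assay, with a stated time of 72 h; a lower number here means a stronger inhibitor, a higher number a weaker inhibitor. Among the three numbers, compound 3 has the second highest; its value sits close to that of compound 1, within the usual scatter, while compound 2 gives a clearly lower number, beyond the scatter.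

Compound 4 `O=S(=O)(Nc1ccccn1)c1ccc(Nc2nncc3ccccc23)cc1` has not yet been measured. It differs from compound 3 in one place: pyridin-2-yl in place of 5-methyl-1,2-oxazol-3-yl on a sulfonamide nitrogen. Both groups are single aromatic rings of the same size in heavy atoms, attached at the same sulfonamide nitrogen. Among the measured compounds shown here, with no measured step of this kind to lean on, the expectation is a change no larger than the scatter, in either direction. Compound 4 is therefore estimated at 8 nM, with a range of 3 nM to 25 nM, which means an expected step of a 1.2-fold higher number from compound 3 to compound 4 (0.08 log units; within the scatter).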

Compound 4, half-maximal inhibitory concentration: 0.9 nM
Compound 4: the middle estimate sits 8.9-fold (0.95 log units) above what was measured, outside the stated range (below it).
By their numbers in this assay, from the lowest: compounds 2 and 4 (each within the scatter of the next); then compounds 3 and 1 (each within the scatter of the next).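

In this assay, the group on the sulfonamide nitrogen clearly matters: pyridin-2-yl in place of 5-methyl-1,2-oxazol-3-yl gives a 7.4-fold lower number from compound 3 to compound 4 (0.87 log units; beyond the scatter). Two aromatic rings with the same count of heavy atoms, attached at the same place, are therefore not interchangeable here. Nothing available explains why the two rings differ.

The compounds shown leave open whether the nitrogen of pyridin-2-yl is needed, which a plain phenyl ring or pyridin-3-yl could test. They also leave open whether any ring is needed, which a methyl group could test.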